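The source may hold more compounds than are shown below. What is called first, only, known or untested is meant among the compounds shown, and "the series" means these compounds.

Measured in an assay on HEK293 cells for positive allosteric modulation of metabotropic glutamate receptor 2 (Rattus norvegicus), read by thallium flux; on this read-out higher numbers stand for larger maximal responses and lower numbers for smaller maximal responses:

- compound 1 `O=C(O)c1cc(-c2cccc(COc3ccc4c(c3)CN(C3CCCC3)C4=O)c2)ccc1O` gives 90.1%
- compound 2 `O=C(O)c1cc(-c2cccc(COc3ccc4c(=O)n(C5CCC5)sc4c3)c2)ccc1Cl` gives 83%
- compound 3 `O=C(O)c1cc(F)cc(-c2cccc(COc3ccc4c(c3)CN(C3CCCC3)C4=O)c2)c1` gives 80.8%

All three numbers lie close together. Compound 2 sits with its value between those of compound 1 and compound 3, and the gaps to both stay inside the usual scatter, so the three compounds cannot be told apart on this read-out.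

Compound 4 `O=C(O)c1cc(-c2cccc(COc3ccc4c(=O)n(CC5CC5)sc4c3)c2)ccc1Cl` is the next compound. It differs from compound 2 only in the group on the aromatic nitrogen of the shared core: cyclopropylmethyl in place of cyclobutyl on an aromatic nitrogen.

For the measured compounds named here, only one step between measured compounds is available, a number 9.3 percentage points lower from compound 1 to compound 3 (within the scatter), and it concerns a change of the substituted phenyl ring on a different core, not the group on the aromatic nitrogen. Going by the values given here, no measured step touches the position that changes between compound 2 and compound 4. Among the compounds with values here, with the one measured change falling within the scatter and no information on this position, no step beyond the scatter is expected here either.

Compound 4 is therefore expected to give about 83% in this assay, with a likely range of 68% to 96%, which means an estimated step of no change at the digits printed from compound 2 to compound 4 (within the scatter).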

Compound 4, largest response reached (reported as percent of maximum), in percent of the reference or control that the assay uses: 38.4%
Compound 4: the middle estimate sits 44.6 percentage points above what was measured; the whole stated range lies above it.
By their numbers in this assay, from the lowest: compound 4; then compounds 3, 2 and 1 (each within the scatter of the next).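

In this assay, cyclopropylmethyl in place of cyclobutyl on an aromatic nitrogen gives a number 44.6 percentage points lower from compound 2 to compound 4 (beyond the scatter), the first step among these compounds to leave the usual scatter, so this position clearly matters for the maximal response. The two groups match in everything counted here, with 4 heavy atoms, all carbon, no hydrogen-bond donors or acceptors and no net charge, and they differ in how those atoms are joined, as a four-membered ring against a three-membered ring, so a rearrangement of the same atoms is enough to produce a step of this size. Nothing in the data shown accounts for the size of this step.

On these data alone, a single pair cannot show how far the effect extends, and it remains open whether a straight butyl chain or a cyclobutyl ring carrying a hydroxyl group would keep the response of compound 2 or lose it as compound 4 does. Also open, as far as these compounds go, is whether the same exchange would cause a similar loss on the core of compound 1.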